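Moving a fluorine around the benzyl ring of a biotin analogue

This account rests on a few compounds, and the source may have more. Where it says the series, first, only, none or still open, it means among the compounds named here.

Compound 1, `COc1cccc(Cn2cc(CCCCC[C@@H]3SC[C@@H]4NC(=O)N[C@@H]43)nn2)c1`, in an assay on isolated protein for inhibition of biotin--protein ligase (Homo sapiens), read by scintillation counting, with a stated time of 10 min (on this read-out higher numbers stand for weaker inhibition and lower numbers for stronger inhibition), gives > 16000 nM, a limit of the assay.
Compound 2, `O=C1N[C@H]2[C@H](CS[C@H]2CCCCCc2cn(Cc3cccc(C(F)(F)F)c3)nn2)N1`, in this assay gives > 16000 nM, also a limit.
Compound 3, `O=C1N[C@H]2[C@H](CS[C@H]2CCCCCc2cn(Cc3ccccc3F)nn2)N1`, in this assay gives > 16000 nM, again a limit.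

Compound 3 therefore stands nowhere in particular on the numbers shown: it sits at the same limit as the two others, and all three values rest on (the limit of > 16000 nM in this assay, at which 3 of the 3 values shown sit). There is a step that the two limits leave unreadable from compound 1 to compound 3 and there is a step that the two limits leave unreadable from compound 2 to compound 3, so neither the direction nor the size of any change among these three compounds can be read.

Compound 4, `O=C1N[C@H]2[C@H](CS[C@H]2CCCCCc2cn(Cc3cccc(F)c3)nn2)N1`, differs from compound 3 only in where the fluorine sits on the benzyl group: 3-fluorophenyl in place of 2-fluorophenyl on a saturated chain carbon bound to an aromatic nitrogen. Among the measured compounds shown here, no measured step bears on this kind of change, and the two steps that touch compound 3 are unreadable. The expectation for compound 4 in this assay is therefore that it stays at the same limit as compound 3, so that the step that the limit leaves unreadable from compound 3 to compound 4 is not expected to be readable either. Compound 4 is estimated at 30000 nM, between 10000 nM and 100000 nM.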

Compound 4, inhibition constant: > 16000 nM
Compound 4: no number, only a limit; the forecaster's own chance of this, stated with the estimate: 80%; the middle value lies beyond the limit too.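

In this assay compound 4 gives > 16000 nM, which is a limit and not a number. The steps from compounds 1, 2 and 3 to compound 4 therefore cannot be read: the limit of > 16000 nM in this assay, at which 4 of the 4 values shown sit.

On these data alone, whether 3-fluorobenzyl in place of 2-fluorobenzyl changes the inhibition at all, and in which direction, stays open.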